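The source may report more compounds than this note shows. Statements on the series, on what has been measured and on what is new or still open speak of the compounds shown alone.

Three compounds have been measured in a physicochemical assay for acid dissociation:

compound 1, `COc1ccc(F)cc1CNCCCNc1ccnc2cc(Cc3cc(C)cc(C)c3)ccc12`, giving 9.47
compound 2, `COc1ccc(F)cc1CNCCCNc1ccnc2cc(C3CCCCC3)ccc12`, giving 9.47
compound 3, `COc1ccc(F)cc1CNCCCNc1ccnc2cc(Cc3ccc(F)cc3)ccc12`, giving 9.47

Compound 3 stands level with the other two at the digits shown. The step of no change at the digits printed from compound 1 to compound 3 (within the scatter) and the step of no change at the digits printed from compound 2 to compound 3 (within the scatter) are both flat within the scatter, as is no change at the digits printed from compound 1 to compound 2 (within the scatter). All three measured steps exchange the group on an aromatic carbon of the shared core, and none of them moves the read-out beyond the scatter.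

Compound 4, `COc1ccc(F)cc1CNCCCNc1ccnc2cc(Cc3ccccc3)ccc12`, has not yet been measured. It differs from compound 3 by hydrogen in place of fluoro on an aromatic carbon. For the measured compounds named here, no measured step removes a fluoro from this six-membered ring, so the change is not matched exactly. Still, every exchange at this same group, whether to a cyclohexyl, a 3,5-dimethylbenzyl or a 4-fluorobenzyl, has left the read-out where it was, and a change as small as fluoro to hydrogen on that ring is expected to do the same.

The step from compound 3 to compound 4 is therefore estimated at no change at the digits printed from compound 3 to compound 4 (within the scatter), no change beyond the scatter. For compound 4 the value is expected to be 9.47, within a range from 9.17 to 9.77.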

Compound 4, acid dissociation constant: 9.47
Estimate against measurement, compound 4: no gap at the digits printed, and the stated range covers the measured number.
By their numbers in this assay, from the lowest: compounds 1, 2, 3 and 4 (each within the scatter of the next).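

In this assay, for the compounds shown here, taking the fluoro off the ring, para to a large group, gives no change at the digits printed from compound 3 to compound 4 (within the scatter), the first matched step in which a single atom is exchanged on this ring rather than the whole group. The plain benzyl group also reads level with the two other groups at this position, with no change at the digits printed from compound 2 to compound 4 (within the scatter) for benzyl in place of cyclohexyl and no change at the digits printed from compound 1 to compound 4 (within the scatter) for phenyl in place of 3,5-dimethylphenyl. The position now holds a cyclohexyl, a 3,5-dimethylbenzyl, a 4-fluorobenzyl and an unsubstituted benzyl, and across these four compounds no exchange moves this read-out beyond the scatter, with none going against that pattern.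

The compounds shown leave open whether a group at this position that carries an amine or a carboxylic acid, or a longer chain in place of the benzyl, would read level as well. Nothing in the available evidence speaks to why the read-out stays level across these groups.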